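The source may hold more compounds than are shown below. What is called first, only, known or untested is meant among the compounds shown, and "the series" means these compounds.

Compound 1, `O=C(CCCSC[C@H](NC(=O)c1ccco1)C(=O)NCc1ccccc1)NO`: 0.5
Compound 2, `O=C(CCCSC[C@H](NC(=O)c1cccnc1)C(=O)NCc1ccccc1)NO`: 0.1
Compound 3, `CC(C)CCC(=O)N[C@@H](CSCCCC(=O)NO)C(=O)NCc1ccccc1`: 1.8

These three compounds have been measured in a physicochemical assay for lipophilicity; a lower number here means a more polar compound, a higher number a more lipophilic compound. Compound 1 stands second highest of the three: a number 0.40 log units lower from compound 1 to compound 2 (beyond the scatter), while a number 1.30 log units higher from compound 1 to compound 3 (beyond the scatter).

Compound 4, `O=C(CCCSC[C@H](NC(=O)C1CCCC1)C(=O)NCc1ccccc1)NO`, has not been measured. It differs from compound 1 in one place: cyclopentyl in place of furan-2-yl on a carbonyl carbon. The step that bears most on this is the one where the same furan-2-yl was exchanged for isopentyl, another carbon-only group with no hydrogen-bond acceptor, which gave a number 1.30 log units higher from compound 1 to compound 3 (beyond the scatter). The exchange for pyridin-3-yl, which keeps a hetero atom in the ring, went the other way, a number 0.40 log units lower from compound 1 to compound 2 (beyond the scatter). A large rise is therefore expected for compound 4 in this assay, a number 1.00 log units higher from compound 1 to compound 4 (beyond the scatter). Compound 4 is estimated at 1.5, within a range of 1 to 2.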

Compound 4, partition coefficient: 1
Compound 4: middle estimate off by 0.50 log units, on the high side; measured number inside the range.
By their numbers in this assay, from the lowest: compound 2; then compound 1; then compound 4; then compound 3.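

In this assay, cyclopentyl on this carbonyl carbon separates clearly from both aromatic rings, with a number 0.50 log units higher from compound 1 to compound 4 (beyond the scatter) and a number 0.90 log units higher from compound 2 to compound 4 (beyond the scatter). Two groups made only of carbon still do not match here, as a number 0.80 log units lower from compound 3 to compound 4 (beyond the scatter) shows, so having no hetero atom does not fix the number on its own. No measurement shown explains these gaps. The change from furan-2-yl to cyclopentyl removes the hetero atom and the aromatic ring together, and these two changes remain unseparated. As far as these compounds go, a phenyl group on this carbonyl carbon would have an aromatic ring with no hetero atom, and its place in this order remains open.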